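Ethoxycarbonyl to methoxyacetyl swap on the anilide nitrogen

The source may hold more compounds than are shown below. What is called first, only, known or untested is meant among the compounds shown, and "the series" means these compounds.

Measured so far:
compound 1, `CONC(=O)c1cc(C/N=C(\S)NCc2ccc(C(C)(C)C)cc2)ccc1NS(C)(=O)=O`, > 30000 nM
compound 2, `CCOC(=O)Nc1ccc(C/N=C(\S)NCc2ccc(C(C)(C)C)cc2)cc1F`, > 30000 nM

In an assay for inhibition of transient receptor potential cation channel subfamily V member 1 (Rattus norvegicus), with a stated time of 10 min (a higher number here means a weaker inhibitor, a lower number a stronger inhibitor), compound 1 gives only a limit, > 30000 nM. Compound 2 likewise gives only a limit in this assay, > 30000 nM. Both sit at the limit of > 30000 nM in this assay, at which 2 of the 2 values shown sit, so compound 2 stands at the edge of what the assay reports, with no number to compare. Compound 3, `COCC(=O)Nc1ccc(C/N=C(\S)NCc2ccc(C(C)(C)C)cc2)cc1F`, differs from compound 2 by methoxymethyl in place of ethoxy on a carbonyl carbon. For the measured compounds named here, no measured step covers such a change. In this assay the change is expected to give no step beyond the scatter, a step that the limit leaves unreadable from compound 2 to compound 3. Compound 3 is therefore estimated at 40000 nM, range 10000 nM to 150000 nM, most probably again reported as a limit.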

Compound 3, half-maximal inhibitory concentration: 10900 nM
Beside the measured number, compound 3's estimate is 3.7-fold (0.56 log units) above it; measured number inside the range.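

In this assay, methoxymethyl in place of ethoxy on a carbonyl carbon gives an at least 2.7-fold lower number from compound 2 to compound 3 (0.43 log units; beyond the scatter), so this position can move the read-out. The leaving and entering groups match in the counts of heavy atoms, donors and acceptors, so the same atoms joined differently are enough for a step beyond the scatter. Compound 3 alone gives a number rather than a limit: the limit of > 30000 nM in this assay, at which 2 of the 3 values shown sit.

Going by these compounds, the full size of the step stays open, since compound 2 gives only a limit. Also open, on these data alone, is whether a longer chain such as methoxyethyl, or an amine such as dimethylaminomethyl, on the same carbonyl carbon would lower the number further.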